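A few compounds are considered here, and "the series" means these few. Any claim that something is new, unique, unknown or untested is made for them only; others in the source may bear on it.

For the measured compounds named here, compound 2 `COc1ccc(CN2CCN(CC(=O)Nc3ccc(-c4nc(-c5ccccc5)c(-c5ccccc5)n4C)cc3)CC2)cc1` stands at the top of the two numbers measured so far. In a functional assay on MCF7 cells (Homo sapiens) for cytotoxicity, read by MTT assay, with a stated time of 24 h, tested at 1.6 ug/mL (a higher number here means a stronger effect of the compound at the concentration tested, a lower number a weaker effect), compound 2 gives 27.3%. Going by the values given here, the only other measured compound is compound 1 `CN1CCN(CC(=O)Nc2ccc(-c3nc(-c4ccccc4)c(-c4ccccc4)n3C)cc2)CC1`; in this assay compound 1 gives 2.9%. Among the compounds with values here, the single measured step, a number 24.4 percentage points higher from compound 1 to compound 2 (beyond the scatter), comes from adding a whole 4-methoxyphenyl group where before there was only hydrogen.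

Compound 3 `Cn1c(-c2ccc(NC(=O)CN3CCN(Cc4ccc(Cl)cc4)CC3)cc2)nc(-c2ccccc2)c1-c1ccccc1` has not yet been measured. It differs from compound 2 in one place: chloro in place of methoxy on an aromatic carbon. This swap, 4-methoxybenzyl to 4-chlorobenzyl, is not the kind of change covered by the measured step, which compared the presence and absence of the 4-methoxyphenyl group rather than what sits on it. No measured step therefore bears directly on this change, and the data give no reason to expect a shift beyond the scatter in either direction. The step expected from compound 2 to compound 3 in this assay is a number 0.3 percentage points lower from compound 2 to compound 3 (within the scatter). Compound 3 is accordingly estimated at 27% in this assay, with a range from 10% to 45%.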

Compound 3, a percentage reported as activity, at one concentration (the size of the read-out at that concentration, not a potency): 11.8%
The estimate for compound 3 lay 15.2 percentage points above the measured number; low and high end bracket the measured number.
By their numbers in this assay, from the lowest: compounds 1 and 3 (each within the scatter of the next); then compound 2.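

In this assay, the group on the aromatic carbon para to a large group makes a clear difference: chloro in place of methoxy gives a number 15.5 percentage points lower from compound 2 to compound 3 (beyond the scatter). For the compounds shown here, the earlier step showed only that the whole 4-methoxyphenyl group counted, whereas this result shows that the outcome depends on what that ring carries, and not merely on the ring being there. Adding 4-chlorophenyl in place of hydrogen gives a number 8.9 percentage points higher from compound 1 to compound 3 (within the scatter), so compound 1 and compound 3 cannot be told apart in this assay, unlike the pair in a number 24.4 percentage points higher from compound 1 to compound 2 (beyond the scatter); no supporting data are available to explain this difference between methoxy and chloro.

With only methoxy and chloro to compare at this place, the compounds shown leave open whether the effect follows the oxygen of the methoxy group, and a hydroxyl group or an amine on the same aromatic carbon could help test that. They also leave open how an ethoxy group, a longer chain ending in the same oxygen, would compare with methoxy in this series.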